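This account rests on a few compounds, and the source may have more. Where it says the series, first, only, none or still open, it means among the compounds named here.

Working notes on the series.

Compound 1 `Clc1ccc(Cl)c(-c2nc(N3CCCCC3)c3nc[nH]c3n2)c1` carries a 2,5-dichlorophenyl group on the unmethylated core. In an assay on cells for displacement of a labelled ligand from adenosine receptor A3 (Homo sapiens), read by scintillation counting and radioligand binding, with a stated time of 180 min, tested at 10 uM (on this read-out lower numbers stand for less inhibition and higher numbers for more inhibition at the one concentration tested (going by the name of the read-out)), compound 1 reaches the upper limit of the assay, reported as > 80%, which is a limit and not a number. Compound 2 `Cn1cnc2c(N3CCCCC3)nc(-c3cccc(O)c3O)nc21` has the methylated core and a 2,3-dihydroxyphenyl group. In this assay, going by the values given here, compound 2 gives 33.7%, the only plain number in the set so far. The other entry, that of compound 1, is a limit: the limit of > 80% in this assay, at which 1 of the 2 values shown sits.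

Compound 3 `Cn1cnc2c(N3CCCCC3)nc(-c3cc(Cl)ccc3Cl)nc21` keeps the methylated core of compound 2 and changes the aryl group: 2,5-dichlorophenyl in place of 2,3-dihydroxyphenyl on an aromatic carbon. Among the compounds with values here, no measured pair in the set differs in one place only, so the size of this step has not been seen directly.

The expectation for compound 3 is an increase in this assay beyond the usual scatter, the step from compound 2 being estimated at a number 41.3 percentage points higher from compound 2 to compound 3 (beyond the scatter), because compound 1, which also carries the 2,5-dichlorophenyl group, reaches > 80%. Compound 3 is accordingly expected to give about 75% in this assay, with a likely range from 50% to 95%, and a fair chance that only the limit is reported.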

Compound 3, a percentage reported as inhibition, at one concentration (the size of the read-out at that concentration, not a potency): 5.4%
Beside the measured number, compound 3's estimate is 69.6 percentage points above it, outside the stated range (below it).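

In this assay the 2,5-dichlorophenyl group does not bring the high reading of compound 1 to the methylated core: at the aromatic carbon between two ring nitrogen atoms, replacing 2,3-dihydroxyphenyl gives a number 28.3 percentage points lower from compound 2 to compound 3 (beyond the scatter) on that core. With the 2,5-dichlorophenyl group held constant, methyl in place of hydrogen on the aromatic nitrogen gives a number at least 74.6 percentage points lower from compound 1 to compound 3 (beyond the scatter), so the outcome of the aryl group depends on which core carries it in these compounds. The reading of compound 1 is a limit and not a number, and the step from it is a bound and not an exact size: the limit of > 80% in this assay, at which 1 of the 3 values shown sits.

The compounds shown do not tell whether the methyl step would hold with 2,3-dihydroxyphenyl on the unmethylated core, and the pair needed to set the two aryl groups side by side on that core is absent here. Nor do they tell how an ethyl group on the same nitrogen, or an amine or a carboxylic acid on the aryl ring, would read in this assay at this position.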